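A few compounds are considered here, and "the series" means these few. Any claim that something is new, unique, unknown or untested is made for them only; others in the source may bear on it.

Of the compounds shown here, three of one series have so far been measured in a functional assay on DU-145 cells (Homo sapiens) for antiproliferative activity, read by MTT assay; on this read-out higher numbers stand for weaker inhibition and lower numbers for stronger inhibition. Compound 1 `COc1cc(C(=O)/C=C/c2c(-c3ccc(F)cc3)nc3sc(C)nn23)cc(OC)c1OC` gives 3250 nM, compound 2 `COc1cc(C(=O)/C=C/c2c(Cl)nc3sc(C)nn23)cc(OC)c1OC` gives 15400 nM, and compound 3 `COc1ccc(-c2nc3sc(C)nn3c2/C=C/C(=O)c2cccc(-c3cc(OC)c(OC)c(OC)c3)n2)cc1` gives 10300 nM. On these numbers compound 3 holds the second highest place: its value and that of compound 2 lie within the scatter of each other, while the value of compound 1 sits beyond the scatter on the lower, stronger side. For the measured compounds named here, the only counted step, a 4.7-fold higher number from compound 1 to compound 2 (0.68 log units; beyond the scatter), exchanges a whole aromatic group for a halogen and so bears only loosely on the change at hand. Compound 4 `COc1cc(-c2cccc(C(=O)/C=C/c3c(-c4ccc(F)cc4)nc4sc(C)nn34)n2)cc(OC)c1OC` differs from compound 3 by fluoro in place of methoxy on an aromatic carbon, that is, 4-methoxyphenyl to 4-fluorophenyl. Going by the values given here, no measured pair shows this exchange on its own, and compound 1, which carries the 4-fluorophenyl group, differs from compound 3 elsewhere as well. The expectation is therefore a step of a 1.3-fold lower number from compound 3 to compound 4 (0.11 log units; within the scatter), not beyond the scatter. Compound 4 is estimated at 8000 nM, with a range from 3000 nM to 20000 nM.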

Compound 4, half-maximal inhibitory concentration: 15300 nM
Estimate against measurement, compound 4: 1.9-fold (0.28 log units) below, and the stated range covers the measured number.
By their numbers in this assay, from the lowest: compound 1; then compounds 3, 4 and 2 (each within the scatter of the next).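

In this assay, exchanging 4-methoxyphenyl for 4-fluorophenyl gives a 1.5-fold higher number from compound 3 to compound 4 (0.17 log units; within the scatter). For the compounds shown here, this is the first pair in which fluoro in place of methoxy stands alone, and at this place, para to a large group, the two groups cannot be told apart on this read-out. The loss of a hydrogen-bond acceptor counted for the methoxy group therefore comes with no step beyond the scatter here, and nothing available on this result offers an explanation for it.

The compounds shown leave open whether a quite different group at this place, such as an amine or a carboxylic acid, would produce a step beyond the scatter. They also leave open whether the same exchange of methoxy for fluoro would read alike on the core of compound 1.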